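A few compounds are considered here, and "the series" means these few. Any claim that something is new, unique, unknown or untested is made for them only; others in the source may bear on it.

Working notes on the series. In a functional assay on CNE-2 cells (Homo sapiens) for antiproliferative activity, read by sulforhodamine B assay, with a stated time of 48 h (a higher number here means a weaker inhibitor, a lower number a stronger inhibitor), compound 1 (`COc1cc(C=C(C(=O)/C=C/c2cccc(OC)c2OC)C(=O)/C=C/c2cccc(OC)c2OC)ccc1O`) gives 280 nM, and compound 2 (`COc1ccc(C=C(C(=O)/C=C/c2cccc(OC)c2OC)C(=O)/C=C/c2cccc(OC)c2OC)cc1OC`) gives 280 nM, level with compound 1. Compound 3 (`COc1cccc(/C=C/C(=O)C(=Cc2cc(OC)c(OC)c(OC)c2)C(=O)/C=C/c2cccc(OC)c2OC)c1OC`) carries methoxy in place of hydrogen on an aromatic carbon of compound 2: methoxy in place of hydrogen on an aromatic carbon. Within the data shown here, only one measured step bears on this, no change at the digits printed from compound 1 to compound 2 (within the scatter), and it is a different change, methyl in place of hydrogen on an oxygen on an aromatic ring. No step beyond the scatter is therefore expected in this assay, and no direction is favoured. The expected step is no change at the digits printed from compound 2 to compound 3 (within the scatter). The estimate for compound 3 is 280 nM, with an expected range of 110 nM to 700 nM.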

Compound 3, half-maximal inhibitory concentration: 400 nM
Beside the measured number, compound 3's estimate is 1.4-fold (0.15 log units) below it; the range from low to high includes it.
By their numbers in this assay, from the lowest: compounds 1, 2 and 3 (each within the scatter of the next).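

In this assay the methoxy entering on the aromatic carbon, which turns 3,4-dimethoxyphenyl into 3,4,5-trimethoxyphenyl, gives a 1.4-fold higher number from compound 2 to compound 3 (0.15 log units; within the scatter) and so adds a third substituent to this ring without a step beyond the scatter. Replacing 4-hydroxy-3-methoxyphenyl with 3,4,5-trimethoxyphenyl gives a 1.4-fold higher number from compound 1 to compound 3 (0.15 log units; within the scatter) and likewise stays within the scatter. Nothing available gives a cause for this result.

From the compounds shown here alone, whether this aromatic carbon accepts groups other than methoxy remains open. An amine, a carboxylic acid or a longer alkoxy chain there could show how far this flat response extends.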